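The compounds below may be only part of what the source reports. "The series", "measured", "known", "first", "only" and "open" are said of these compounds alone.

In a toxicity assay on the whole organism (J774 cells) for cytotoxicity, with Mus musculus as the target, read by MTT assay, with a stated time of 24 h, tested at 10 uM (a lower number here means a stronger effect, a higher number a weaker effect of the compound at the concentration tested), the three measured compounds give these numbers:

Compound 1 `CCCCCCCCCO[C@@H]1[C@@H](N)[C@@H](O[C@H]2[C@H](O)[C@@H](O)[C@H](N)C[C@@H]2N)O[C@H](CN)[C@H]1OCCCCCCCCC` gives 82.7%.
Compound 2 `CCCCCCCCCO[C@@H]1[C@@H](N)[C@@H](OCC(O)CO)O[C@H](CN)[C@H]1OCCCCCCCCC` gives 89.7%.
Compound 3 `CCCCCCCCCO[C@@H]1[C@@H](N)[C@@H](OCC(O)CNCCCN)O[C@H](CN)[C@H]1OCCCCCCCCC` gives 101%.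

Compound 3 stands highest of the three: the steps of a number 18.3 percentage points higher from compound 1 to compound 3 (beyond the scatter) and a number 11.3 percentage points higher from compound 2 to compound 3 (beyond the scatter) are both beyond the scatter, so compound 3 is the weakest of the three in this assay. Compound 4 `CCCCCCCCCO[C@@H]1[C@@H](N)[C@@H](OC[C@H](O)CN)O[C@H](CN)[C@H]1OCCCCCCCCC` is the next step from compound 3: 2-amino-1-hydroxyethyl in place of 2-((3-aminopropyl)amino)-1-hydroxyethyl on a saturated chain carbon bound to an oxygen on a saturated carbon. Among the measured compounds shown here, the only measured step that bears on it is a number 11.3 percentage points higher from compound 2 to compound 3 (beyond the scatter), where the (3-aminopropyl)amino group entered. Compound 4 keeps an amine at that position but loses the aminopropyl chain, so part of that modest rise is expected to be given back, with compound 4 landing between compound 2 and compound 3. The step of a number 6 percentage points lower from compound 3 to compound 4 (within the scatter) is therefore expected to be small and downward. Compound 4 is estimated at 95%, within 84% to 106%.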

Compound 4, a percentage reported as activity, at one concentration (the size of the read-out at that concentration, not a potency): 88%
The estimate for compound 4 lay 7 percentage points above the measured number; low and high end bracket the measured number.
By their numbers in this assay, from the lowest: compounds 1, 4 and 2 (each within the scatter of the next); then compound 3.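

In this assay, cutting 3-((3-aminopropyl)amino)-2-hydroxypropyl back to 3-amino-2-hydroxypropyl gives a number 13 percentage points lower from compound 3 to compound 4 (beyond the scatter), so the higher number of compound 3 goes with the full side chain, not with an amine at this place alone. An amine in place of hydroxy gives only a number 1.7 percentage points lower from compound 2 to compound 4 (within the scatter), and replacing the 4,6-diamino-2,3-dihydroxycyclohexyl group gives a number 5.3 percentage points higher from compound 1 to compound 4 (within the scatter). No data here explain these steps. As far as these compounds go, whether the second amine or the added chain goes with the higher number of compound 3 stays open; a plain propyl group on that amine would separate the two.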